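Working notes on a trimethoxyphenyl substitution

A few compounds are considered here, and "the series" means these few. Any claim that something is new, unique, unknown or untested is made for them only; others in the source may bear on it.

Two members of the series have numbers in a functional assay on A549 cells (Homo sapiens) for antiproliferative activity, read by MTT assay, with a stated time of 24 h; a lower number here means a stronger inhibitor, a higher number a weaker inhibitor. Compound 1 `COc1ccc(-c2cc(C(=O)/C=C/c3ccccc3)nc3cc(-c4ccccc4)nn23)cc1OC` gives 18600 nM in this assay. Compound 2 `COc1ccc(C(=O)/C=C/c2cc(-c3cc(OC)c(OC)c(OC)c3)n3nc(-c4ccccc4)cc3n2)cc1` gives 14600 nM in this assay. Within the data shown here, compound 2 holds the lower of the two numbers, but the two values lie within the scatter of each other, so no order can be read from them; compound 1 and compound 2 differ in more than one place and no single step connects them.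

Compound 3 `COc1cc(C(=O)/C=C/c2cc(-c3cc(OC)c(OC)c(OC)c3)n3nc(-c4ccccc4)cc3n2)cc(OC)c1OC` has not yet been measured in this assay. It differs from compound 2 in one place: 3,4,5-trimethoxyphenyl in place of 4-methoxyphenyl on a carbonyl carbon. No measured pair in the series shows this change, so there is no shown step to lean on. Without such a step the expectation is a small step, if any, toward a lower number, not clearly beyond the scatter. For compound 3 the estimated value in this assay is 10000 nM, with a range from 3000 nM to 30000 nM. The estimated step of a 1.5-fold lower number from compound 2 to compound 3 (0.16 log units; within the scatter) is expected to be small.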

Compound 3, half-maximal inhibitory concentration: 20500 nM
Beside the measured number, compound 3's estimate is 2.1-fold (0.31 log units) below it; the range from low to high includes it.
By their numbers in this assay, from the lowest: compounds 2, 1 and 3 (each within the scatter of the next).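

In this assay, the series now has its first step between compounds that differ in one place: on the carbonyl carbon whose other neighbour is the double-bonded chain carbon, 3,4,5-trimethoxyphenyl in place of 4-methoxyphenyl gives a 1.4-fold higher number from compound 2 to compound 3 (0.15 log units; within the scatter). This position therefore carries either group, 12 heavy atoms and 3 hydrogen-bond acceptors or 8 heavy atoms and 1 hydrogen-bond acceptor, with no order readable between the two compounds, so adding methoxy groups to this ring shows no effect that can be separated from the scatter. No measurement is at hand that could explain the size of this step.

This single step cannot show whether the position responds to anything other than a methoxy-bearing phenyl ring, since compound 2 and compound 3 both carry one there. Still open, as far as these compounds go, is whether an amine or a carboxylic acid on that ring, or a small alkyl chain in place of the ring on the carbonyl carbon, would produce a step beyond the scatter.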